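Sulfonyl substituent and ring chloro in a covalent anilinopyrimidine series

The compounds below may be only part of what the source reports. "The series", "measured", "known", "first", "only" and "open" are said of these compounds alone.

Measured so far:
compound 1 `C=CC(=O)Nc1cc(Nc2ncc(Cl)c(Nc3ccccc3S(=O)(=O)C(C)C)n2)c(OC)cc1N(C)CCN(C)C`: 12%
compound 2 `C=CC(=O)Nc1cc(Nc2ncc(Cl)c(Nc3ccccc3S(=O)(=O)N(C)C)n2)c(OC)cc1N(C)CCN(C)C`: 23%
compound 3 `C=CC(=O)Nc1cc(Nc2nccc(Nc3ccccc3S(=O)(=O)N(C)C)n2)c(OC)cc1N(C)CCN(C)C`: 5%

In an ADME assay on microsomes from liver (Mus musculus) for metabolic stability, read by LC-MS, using NADPH, with a stated time of 30 min, tested at 1 uM (on this read-out higher numbers stand for a more stable compound and lower numbers for a less stable compound), compound 2 gives 23%. Compound 1 carries isopropyl in place of dimethylamino on a sulfonyl sulfur; in this assay compound 1 gives 12%, and the step is a number 11 percentage points lower from compound 2 to compound 1 (beyond the scatter). Compound 3 differs from compound 2 in the core, (hydrogen in place of chloro on an aromatic carbon); in this assay compound 3 gives 5%, the step being a number 18 percentage points lower from compound 2 to compound 3 (beyond the scatter). Compound 3 and compound 1 lie within the scatter of each other, so no order between them is claimed.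

Compound 4 `C=CC(=O)Nc1cc(Nc2nccc(Nc3ccccc3S(=O)(=O)C(C)C)n2)c(OC)cc1N(C)CCN(C)C` is not yet measured. It stands to compound 3 as compound 1 stands to compound 2: isopropyl in place of dimethylamino on a sulfonyl sulfur, the same change at the same place, now on the core of compound 3. Within the data shown here, the only step of this change on record is a number 11 percentage points lower from compound 2 to compound 1 (beyond the scatter), a single observation. The step from compound 3 to compound 4 is expected to be a number 2 percentage points lower from compound 3 to compound 4 (within the scatter), smaller in size than that earlier step because compound 3 already stands at 5% and little room lies below it. Compound 4 is expected to give 3% in this assay, within a range of 0% to 12%.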

Compound 4, percent of the compound remaining: 8%
Estimate against measurement, compound 4: 5 percentage points below, and the stated range covers the measured number.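

On the core of compound 3, isopropyl in place of dimethylamino on the sulfonyl sulfur gives a number 3 percentage points higher from compound 3 to compound 4 (within the scatter), and the gap to the same change on the chloro core does not separate the two: the same change on two cores in this assay, a number 11 percentage points lower (beyond the scatter) from compound 2 to compound 1 and a number 3 percentage points higher (within the scatter) from compound 3 to compound 4, 14 percentage points apart, within the scatter of two such steps. Hydrogen in place of chloro, read on the isopropyl pair, gives a number 4 percentage points lower from compound 1 to compound 4 (within the scatter), and this step likewise does not separate from its earlier counterpart: the same change on two cores in this assay, a number 18 percentage points lower (beyond the scatter) from compound 2 to compound 3 and a number 4 percentage points lower (within the scatter) from compound 1 to compound 4, 14 percentage points apart, within the scatter of two such steps. No difference between cores is shown for either change, but transfer is not proved either: each comparison rests on a single pair of steps, and in this assay compound 3 at 5% and compound 4 at 8% both lie near the bottom of the read-out, which leaves little range in which a step could show.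

The compounds shown hold only two groups on the sulfonyl sulfur and only chloro or hydrogen on the core. As far as these compounds go, what a cyclic amine such as morpholine or a longer alkyl chain on the sulfonyl sulfur, or fluoro or methyl in place of chloro, would give in this assay stays open.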